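This account rests on a few compounds, and the source may have more. Where it says the series, first, only, none or still open, it means among the compounds named here.

Compound 1, `C/C=C/C=C/C(=O)N(Cc1ccc(OC)c(O)c1)c1cc(OC)c(OC)c(OC)c1`: 180 nM in a functional assay on HCT-116 cells (Homo sapiens) for inhibition, read by MTT assay, with a stated time of 48 h; on this read-out higher numbers stand for weaker inhibition and lower numbers for stronger inhibition
Compound 2, `COc1ccc(CN(C(=O)/C=C/CBr)c2cc(OC)c(OC)c(OC)c2)cc1O`: 59 nM
Compound 3, `COCC(=O)N(Cc1ccc(OC)c(O)c1)c1cc(OC)c(OC)c(OC)c1`: 230 nM

Compound 3 gives the highest of the three numbers in this assay. Its nearest neighbour is compound 1, with a 1.3-fold higher number from compound 1 to compound 3 (0.11 log units; within the scatter), a step within the scatter; the furthest is compound 2, with a 3.9-fold higher number from compound 2 to compound 3 (0.59 log units; beyond the scatter), a step beyond the scatter.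

Compound 4, `CCCCC(=O)N(Cc1ccc(OC)c(O)c1)c1cc(OC)c(OC)c(OC)c1`, is not yet measured. It differs from compound 3 by propyl in place of methoxy on a saturated chain carbon bound to a carbonyl carbon, which, read one bond further out, is methoxymethyl to butyl on the carbonyl carbon.

Among the measured compounds shown here, no measured step swaps methoxy for propyl. For the measured compounds named here, the steps that bear on it are those at the carbonyl carbon: from compound 1 to compound 3 the whole group on that carbon was exchanged and the number moved only within the scatter, while from compound 2 to compound 3 the exchange gave a modest step. The change to compound 4 is smaller than either of those. The expected step of a 1.1-fold higher number from compound 3 to compound 4 (0.04 log units; within the scatter) is therefore none beyond the scatter. Compound 4 is expected to give 250 nM in this assay, between 110 nM and 560 nM.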

Compound 4, half-maximal inhibitory concentration: 170 nM
The estimate for compound 4 lay 1.5-fold (0.17 log units) above the measured number; low and high end bracket the measured number.
By their numbers in this assay, from the lowest: compound 2; then compounds 4, 1 and 3 (each within the scatter of the next).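

In this assay, the chain at this place need not carry the methoxy oxygen: with propyl in its place on the saturated chain carbon bound to the carbonyl carbon, the result is a 1.4-fold lower number from compound 3 to compound 4 (0.13 log units; within the scatter), a step within the scatter. The fully saturated butyl group on the carbonyl carbon also stays within the scatter of the penta-1,3-dien-1-yl group, at a 1.1-fold lower number from compound 1 to compound 4 (0.02 log units; within the scatter), but remains apart from the 3-bromoprop-1-en-1-yl group, at a 2.9-fold higher number from compound 2 to compound 4 (0.46 log units; beyond the scatter), so compound 2 alone stands beyond the scatter of the other three. Nothing available explains these numbers.

The compounds shown do not separate the part played by the bromine from that of the double bond in compound 2. Going by these compounds, how a chain longer than butyl, or an amine at the end of the chain, would read in this assay remains open.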